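Ethylsulfanyl for fluoro on the pyridine-bearing series

The source may hold more compounds than are shown below. What is called first, only, known or untested is meant among the compounds shown, and "the series" means these compounds.

Working notes. Three compounds have been run in a functional assay on Jurkat cells (Homo sapiens) for activation, with a stated time of 24 h; on this read-out lower numbers stand for an effect already at smaller amounts and higher numbers for an effect only at larger amounts of compound: compound 1 `CN(Cc1ccccc1O)c1ccc(C2CCCCC2)cc1` and compound 2 `Oc1ccccc1CNc1ccc(-c2cccc(OC(F)(F)F)c2)cc1` were both recorded as not active there, compound 1 giving "not active" (no number reported) and compound 2 giving "not active" (no number reported). Going by the values given here, compound 3 `Oc1ccccc1CNc1ccc(-c2ccc(F)cc2)nc1` is the only entry with a number: in this assay compound 3 gives 2590 nM, so it stands as the sole measured point of reference.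

Compound 4 `CCSc1ccc(-c2ccc(NCc3ccccc3O)cn2)cc1` differs from compound 3 by ethylsulfanyl in place of fluoro on an aromatic carbon, in words ethylsulfanyl in place of fluoro on an aromatic carbon. Among the compounds with values here, no comparable step has been measured, so the size is uncertain; a change roughly at the edge of the scatter, tending toward an effect at smaller amounts, is expected, i.e. the expected step is a 1.7-fold lower number from compound 3 to compound 4 (0.24 log units; within the scatter). For compound 4 the estimate in this assay is 1500 nM, with a range from 400 nM to 6000 nM.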

Compound 4, half-maximal effective concentration: 1920 nM
The estimate for compound 4 lay 1.3-fold (0.11 log units) below the measured number; the range from low to high includes it.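

In this assay, ethylsulfanyl in place of fluoro on this aromatic carbon, para to a large group, gives a 1.3-fold lower number from compound 3 to compound 4 (0.13 log units; within the scatter). This position therefore accepts the larger group with a numerical value retained, and compound 4 adds a second measured point to the series. No measured property of either group is available to account for this result.

Still open, on these data alone, is whether an amine, a carboxylic acid or a longer chain on this carbon would stay within the scatter of compound 3 or move beyond it. A single step also leaves open whether the same change would behave alike on another core.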